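A few compounds are considered here, and "the series" means these few. Any claim that something is new, unique, unknown or untested is made for them only; others in the source may bear on it.

In a functional assay on B16-F10 cells (Mus musculus) for cytotoxicity (a higher number here means a weaker inhibitor, a lower number a stronger inhibitor), compound 1 `O=c1oc2ccccc2c2nc3c(ccc4cc[nH]c43)c(-c3ccc(O)cc3)c12` gives 70700 nM. This is level with compound 2 `O=c1cc(O)c2cc(Cl)ccc2o1`, a much smaller structure, which gives 70700 nM. Both numbers are large on this scale, so neither compound is a strong inhibitor of these cells.

Compound 3 `O=c1oc2ccccc2c2nc3c(ccc4cc[nH]c43)c(-c3ccc(Cl)cc3)c12` keeps the core of compound 1 and differs in one place: chloro in place of hydroxy on an aromatic carbon. The change sits para to a large group, and it turns the 4-hydroxyphenyl of compound 1 into the 4-chlorophenyl of compound 3.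

Going by the values given here, no measured pair shows this change, so any prediction of its size is uncertain. Compound 2 also carries a chloro on an aromatic carbon and gives 70700 nM, but its structure is too different from compound 3 to serve as a direct guide, and it offers no hint of a large gain. A modest move towards stronger inhibition is expected, although one within the scatter would be no surprise, and the estimated change is a 1.8-fold lower number from compound 1 to compound 3 (0.25 log units; within the scatter). Compound 3 is estimated at 40000 nM, with an expected range from 10000 nM to 110000 nM.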

Compound 3, half-maximal inhibitory concentration: 70700 nM
For compound 3 the middle estimate is 1.8-fold (0.25 log units) below the measured one; the measured number falls inside the stated range.
By their numbers in this assay, from the lowest: compounds 1, 2 and 3 (each within the scatter of the next).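

In this assay, going by these compounds alone, the swap of 4-hydroxyphenyl for 4-chlorophenyl gives the first direct reading of this change on the shared core (no change at the digits printed from compound 1 to compound 3 (within the scatter)). At this spot, on an aromatic carbon para to a large group, the hydroxy brings one hydrogen-bond donor and one acceptor and the chloro brings neither, yet the cell read-out stays put and both compounds remain weak on this scale. This single pair therefore shows that the difference between these two groups does not register here, while no supporting measurement is available to explain that outcome.

On these data alone, whether this position responds to anything at all remains open, since an amine, a carboxylic acid or a methoxy group at the same place could give a different number from the hydroxy and chloro compared here. As far as these compounds go, it also remains open whether the same swap would stay as flat on a version of the core altered elsewhere, since one pair at one position cannot settle how general the result is.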